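Swapping Trifluoromethyl for Chloro on the Shared Core

The source may report more compounds than this note shows. Statements on the series, on what has been measured and on what is new or still open speak of the compounds shown alone.

Compound 1 `COc1ccccc1NC(=O)COc1cc(C)nc2ccc(C(F)(F)F)cc12` was tested in an ADME assay on HepG2 cells (Homo sapiens) for cytotoxicity, read by trypan blue exclusion, with a stated time of 48 h, in the presence of a further agent that is not named here; a lower number here means that less compound is tolerated, a higher number that more compound is tolerated. In this assay compound 1 gives > 128000 nM, which is a limit of the assay rather than a number (the limit of > 128000 nM in this assay, at which 1 of the 3 values shown sits). Compound 2 `COc1ccc(NC(=O)COc2cc(C)nc3ccc(OC)cc23)cc1` also reaches only a limit in this assay, > 142000 nM. Compound 3 `CCCCCNC(=O)COc1cc(C)nc2ccc(OC)cc12` gives 106000 nM in this assay. Within the data shown here, the single measured step, an at least 1.3-fold lower number from compound 2 to compound 3 (0.12 log units; that floor lies within the scatter), alters the amide-type nitrogen and not the ring, so no measured step bears on the change to compound 4 `COc1ccccc1NC(=O)COc1cc(C)nc2ccc(Cl)cc12`: chloro in place of trifluoromethyl on an aromatic carbon. Lacking such a step, no shift beyond the scatter is expected, and compound 4 is estimated at 128000 nM, between 60000 nM and 300000 nM. The expected step is therefore a number no higher from compound 1 to compound 4 (the limit leaves the size open).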

Compound 4, half-maximal cytotoxic concentration: 99200 nM
Beside the measured number, compound 4's estimate is 1.3-fold (0.11 log units) above it, within the range that was stated.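

Among these compounds, this is the only measured step that touches the ring of the shared core rather than the amide-type nitrogen: in this assay, chloro in place of trifluoromethyl on an aromatic carbon gives an at least 1.2-fold lower number from compound 1 to compound 4 (0.11 log units; that floor lies within the scatter). So far, then, the change shows no shift beyond the scatter, but its full size stays open because compound 1 reaches only a limit: the limit of > 128000 nM in this assay, at which 1 of the 4 values shown sits.

On these data alone, an amine or a carboxylic acid on this aromatic carbon remains open. So does whether the same swap would read alike with a different group on the amide-type nitrogen.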